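The compounds below may be only part of what the source reports. "The series", "measured", "known", "first", "only" and "open" are said of these compounds alone.

Measured so far in a functional assay on PC-3 cells (Homo sapiens) for cytotoxicity, read by sulforhodamine B assay, with a stated time of 48 h; on this read-out lower numbers stand for stronger inhibition and higher numbers for weaker inhibition:
- compound 1, `C=CCOc1ccc(F)cc1C(=O)c1cccnc1` — > 100000 nM
- compound 2, `O=C(c1cccnc1)c1cc(Cl)ccc1O` — 24800 nM
- compound 3, `C=CCOc1ccc(Br)cc1C(=O)c1cccnc1` — 59000 nM

The value for compound 1 is a limit of this assay, not a number. Among the two numbers, compound 3 stands highest; nearest is compound 2, whose value lies beyond the scatter below that of compound 3. For the measured compounds named here, the only measured step at the same aromatic position is an at least 1.6-fold lower number from compound 1 to compound 3 (0.22 log units; that floor lies within the scatter), and it starts from the limit (the limit of > 100000 nM in this assay, at which 1 of the 3 values shown sits), so it sets only a floor that lies within the scatter.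

Compound 4, `C=CCOc1ccc(C)cc1C(=O)c1cccnc1`, differs from compound 3 by methyl in place of bromo on an aromatic carbon. Going by the values given here, no measured step covers a bromo to methyl exchange, and the one step at this position is too small to point in a direction. The step from compound 3 to compound 4 is therefore expected to be a 1.0-fold higher number from compound 3 to compound 4 (0.01 log units; within the scatter), that is, none beyond the scatter. Compound 4 is expected to give about 60000 nM in this assay, within a range from 25000 nM to 150000 nM.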

Compound 4, half-maximal inhibitory concentration: 98000 nM
Estimate against measurement, compound 4: 1.6-fold (0.21 log units) below; the range from low to high includes it.
By their numbers in this assay, from the lowest: compound 2; then compounds 3 and 4 (each within the scatter of the next). At a limit, above all of these: compound 1.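

For the compounds shown here, on the aromatic carbon para to the allyloxy group, the earlier compounds offered only a floor, whereas compounds 3 and 4 now give a step between two numbers. In this assay methyl in place of bromo gives a 1.7-fold higher number from compound 3 to compound 4 (0.22 log units; within the scatter) and so does not separate these two groups at this position. Methyl in place of fluoro gives an at least 1.0-fold lower number from compound 1 to compound 4 (0.00 log units; that floor lies within the scatter) as a floor only, which cannot be read as a step. Compound 1 stands at a limit and not at a number: the limit of > 100000 nM in this assay, at which 1 of the 4 values shown sits.

On these data alone, it remains open whether any group on this carbon, such as an amine or a carboxylic acid, would give a step beyond the scatter. Compound 2 differs from the others in more than one place, so what the allyloxy group itself contributes also stays unresolved.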